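Methylsulfanyl for trifluoromethyl on a slowly cleared compound

The source may hold more compounds than are shown below. What is called first, only, known or untested is meant among the compounds shown, and "the series" means these compounds.

Compound 2 `Cc1cc(Nc2ccc(S(F)(F)(F)(F)F)cc2)n2nc(C(F)(F)F)nc2n1` gives < 5 mL.min-1.g-1 in an in vitro ADME assay on microsomes from liver (Homo sapiens) for metabolic stability (on this read-out higher numbers stand for fast clearance and lower numbers for slow clearance), and that value is a limit of the assay. Compound 1 `Cc1cc(Nc2ccc(C(F)(F)F)cc2)n2nc(CCO)nc2n1` gives < 5 mL.min-1.g-1 in this assay and that value is also a limit. Compound 3 `Cc1cc(Nc2cccc(Cl)c2)n2nc(C(C)(F)F)nc2n1` reads a full number (44.4 mL.min-1.g-1) so compounds with the shared core do not all read alike. Within the data shown here, compound 4 `CSc1nc2nc(C)cc(Nc3ccc(S(F)(F)(F)(F)F)cc3)n2n1` carries methylsulfanyl in place of trifluoromethyl on an aromatic carbon and no measured pair shows this change. The expected step is a modest rise in clearance (an at least 2.0-fold higher number from compound 2 to compound 4 (0.30 log units; that floor lies within the scatter)) and it remains a rough expectation. For compound 4 the estimate is 10 mL.min-1.g-1 (expected range 5 mL.min-1.g-1 to 25 mL.min-1.g-1).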

Compound 4, intrinsic clearance in microsomes: 22.4 mL.min-1.g-1
For compound 4 the middle estimate is 2.2-fold (0.35 log units) below the measured one; the range from low to high includes it.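

Putting methylsulfanyl in place of trifluoromethyl on this aromatic carbon gives an at least 4.4-fold higher number from compound 2 to compound 4 (0.65 log units; beyond the scatter) in this assay. Among these compounds, this is the only measured pair that isolates this position, and it shows that a change here alone can move clearance beyond the scatter. Compound 2 reads at a limit of the assay, so the step has a floor but no known full size: the limit of < 5 mL.min-1.g-1 in this assay, at which 2 of the 4 values shown sit.

Still open, from the compounds shown here alone, is how other groups on this carbon, such as an amine or a methoxy group, would read. The compounds shown also leave open whether the same swap acts alike elsewhere on the shared core.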